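Methylsulfanyl in place of methoxy on the shared core

The source may hold more compounds than are shown below. What is called first, only, known or untested is meant among the compounds shown, and "the series" means these compounds.

Compound 2 `COc1ncnc2c1c(-c1ccoc1)cn2[C@@H]1O[C@H](CO)[C@@H](O)[C@H]1O` gives 110 nM in a functional assay on HCT-116 cells (Homo sapiens), read by MTT assay, with a stated time of 72 h (a higher number here means a weaker inhibitor, a lower number a stronger inhibitor), the lowest of the two numbers shown. Compound 1 `COc1ncnc2c1c(-c1ccsc1)cn2[C@@H]1O[C@H](CO)[C@@H](O)[C@H]1O` gives 120 nM in this assay, and the step of a 1.1-fold lower number from compound 1 to compound 2 (0.04 log units; within the scatter) sits within the scatter. Compound 3 `COc1nc(N)nc2c1c(-c1ccoc1)cn2[C@@H]1O[C@H](CO)[C@@H](O)[C@H]1O` reaches only a limit of this assay, > 20000 nM (the limit of > 20000 nM in this assay, at which 1 of the 3 values shown sits). The step of an at least 180-fold higher number from compound 2 to compound 3 (2.25 log units; beyond the scatter) is large. Compound 4 `CSc1ncnc2c1c(-c1ccoc1)cn2[C@@H]1O[C@H](CO)[C@@H](O)[C@H]1O` carries methylsulfanyl in place of methoxy on an aromatic carbon. Among the measured compounds shown here, no measured step exchanges methoxy for methylsulfanyl; the nearest comparison, furan-3-yl against thiophen-3-yl, stayed within the scatter, while the large step to compound 3 concerns an amino group and does not bear on this change. Compound 4 is therefore expected to show a 1.4-fold higher number from compound 2 to compound 4 (0.13 log units; within the scatter), nothing beyond the scatter. The estimate for compound 4 is 150 nM, ranging from 40 nM to 600 nM.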

Compound 4, half-maximal inhibitory concentration: 40 nM
Beside the measured number, compound 4's estimate is 3.8-fold (0.57 log units) above it; low and high end bracket the measured number.
By their numbers in this assay, from the lowest: compound 4; then compounds 2 and 1 (each within the scatter of the next). At a limit, above all of these: compound 3.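

The methoxy group stayed fixed on this aromatic carbon in compounds 1, 2 and 3, so they showed nothing about the position. In this assay, exchanging it for methylsulfanyl with the furan-3-yl group kept gives a 2.8-fold lower number from compound 2 to compound 4 (0.44 log units; beyond the scatter), so the number at this position moves with the exchange of oxygen for sulfur, and it moves down. Nothing shown here gives a cause for this step.

Going by these compounds, it remains open whether the exchange acts the same way alongside thiophen-3-yl or the amino group of compound 3. Also open, on these data alone, is what a longer chain such as ethylsulfanyl, or an amine, would give on this carbon.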